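The source may hold more compounds than are shown below. What is called first, only, known or untested is meant among the compounds shown, and "the series" means these compounds.

Of the compounds shown here, three sharing one core have been measured in a functional assay on HEK293 cells for antagonist activity at Voltage-dependent L-type calcium channel subunit alpha-1D (Rattus norvegicus), read by FLIPR; on this read-out lower numbers stand for stronger inhibition and higher numbers for weaker inhibition. Compound 1 `CCOC(=O)C1=C(C)NC(COC)=C(C(=O)OC)C1c1ccccc1[N+](=O)[O-]` gives 790 nM, compound 2 `CCOC(=O)C1=C(C)NC(COC)=C(C(=O)OC)C1c1cccc([N+](=O)[O-])c1` gives 96 nM, and compound 3 `CCOC(=O)C1=C(C)NC(CO)=C(C(=O)OCC)C1c1cccc([N+](=O)[O-])c1` gives 45 nM. For the measured compounds named here, the only step between compounds that differ in a single place, an 8.2-fold lower number from compound 1 to compound 2 (0.92 log units; beyond the scatter), concerns the nitrophenyl group on a saturated ring carbon. Compound 3 stands lowest of the three numbers, with compound 2 nearest and compound 1 furthest; compound 2 and compound 3 differ in two places, so their values can only be set side by side. Compound 4 `CCOC(=O)C1=C(C)NC(C(OCC)OCC)=C(C(=O)OCC)C1c1cccc([N+](=O)[O-])c1` has not yet been measured. It differs from compound 3 by diethoxymethyl in place of hydroxymethyl on a double-bonded ring carbon, on a double-bonded ring carbon next to the ring nitrogen. Going by the values given here, no measured step touches this group, and the step from compound 1 to compound 2 concerns a different part of the core, so no direction can be drawn from it. For compound 4 a step of a 1.8-fold higher number from compound 3 to compound 4 (0.25 log units; within the scatter) is expected, hardly beyond the scatter. The estimate for compound 4 in this assay is 80 nM, ranging from 20 nM to 320 nM.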

Compound 4, half-maximal inhibitory concentration: 615 nM
The estimate for compound 4 lay 7.7-fold (0.89 log units) below the measured number, and the stated range ends below it.
By their numbers in this assay, from the lowest: compound 3; then compound 2; then compounds 4 and 1 (each within the scatter of the next).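

In this assay, for the compounds shown here, the group on the double-bonded ring carbon next to the ring nitrogen now has a measured step of its own: diethoxymethyl in place of hydroxymethyl gives a 14-fold higher number from compound 3 to compound 4 (1.14 log units; beyond the scatter), a large change at a position no earlier pair had touched. The two groups differ in more than one way, since diethoxymethyl has more heavy atoms and no hydrogen-bond donor, while hydroxymethyl has one, and this single step cannot separate those differences. Nothing available bears on the reason for this step.

The compounds shown leave open whether size or the hydrogen-bond donor governs the number at this position. They also leave open how an aminomethyl group, a carboxylic acid or a single ethoxymethyl chain would read out here.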